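Trimming the aryl group of a bis(trifluoromethyl)benzenesulfonamide

This account rests on a few compounds, and the source may have more. Where it says the series, first, only, none or still open, it means among the compounds named here.

Compound 2 `O=S(=O)(NCCCNCc1ccc(Cl)c(C(F)(F)F)c1)c1cc(C(F)(F)F)cc(C(F)(F)F)c1` was tested in a toxicity assay on MCF-10A cells (Homo sapiens) for inhibition, read by MTT assay, with a stated time of 72 h (a higher number here means a weaker inhibitor of growth, a lower number a stronger inhibitor of growth), and gives 7900 nM. Among the two numbers shown it stands highest, with compound 1 `COc1ccc(CNCCCNS(=O)(=O)c2cc(C(F)(F)F)cc(C(F)(F)F)c2)cc1OC` nearest: in this assay compound 1 gives 5300 nM, and the step of a 1.5-fold higher number from compound 1 to compound 2 (0.17 log units; within the scatter) lies within the scatter. Compound 3 `O=S(=O)(NCCCNCc1ccc(Cl)cc1)c1cc(C(F)(F)F)cc(C(F)(F)F)c1` differs from compound 2 in one place: hydrogen in place of trifluoromethyl on an aromatic carbon. Among the compounds with values here, the only measured step that bears on this region, the aryl group on the saturated chain carbon bound to the amine nitrogen, is a 1.5-fold higher number from compound 1 to compound 2 (0.17 log units; within the scatter), and that exchange of the whole aryl substitution pattern moved the number by no more than the scatter. The smaller change from compound 2 to compound 3 is therefore expected to move the number by no more than the scatter either, as a step of a 1.1-fold lower number from compound 2 to compound 3 (0.05 log units; within the scatter). Compound 3 is estimated at 7000 nM, within a range from 3500 nM to 14000 nM.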

Compound 3, concentration for 50% growth inhibition: 2300 nM
For compound 3 the middle estimate is 3.0-fold (0.48 log units) above the measured one; the whole stated range lies above it.
By their numbers in this assay, from the lowest: compound 3; then compounds 1 and 2 (each within the scatter of the next).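

In this assay, the aromatic carbon ortho to a chloro group proves to be a place where the number responds: taking off trifluoromethyl there gives a 3.4-fold lower number from compound 2 to compound 3 (0.54 log units; beyond the scatter), a change beyond the scatter. The earlier exchange of the whole aryl group did not show this, as it gave a 1.5-fold higher number from compound 1 to compound 2 (0.17 log units; within the scatter), whereas 4-chlorophenyl in place of 3,4-dimethoxyphenyl gives a 2.3-fold lower number from compound 1 to compound 3 (0.36 log units; beyond the scatter), so the aryl group does affect growth inhibition in these cells. No measurement shown here accounts for these shifts.

From the compounds shown here alone, whether the lower number requires hydrogen on this carbon remains open, since a fluoro group, a methyl group or a nitrile there would test how specific the step is. Also open, going by these compounds, is whether the chloro group is needed at all, and whether the step would hold with a longer chain in the linker.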